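The source may hold more compounds than are shown below. What is called first, only, known or untested is meant among the compounds shown, and "the series" means these compounds.

Measured compounds:
- Compound 1, `COc1ccc(Cc2cnc(CCc3ccc(-c4ccccc4C(=O)O)cc3)[nH]2)cc1`, gives 5360 nM in an in vitro functional assay on cells for agonist activity at Bombesin receptor subtype-3 (Homo sapiens), read by luminescence and calcium flux; on this read-out lower numbers stand for an effect already at smaller amounts and higher numbers for an effect only at larger amounts of compound.
- Compound 2, `O=C(O)c1ccccc1-c1ccc(CCc2ncc(Cc3ccc(F)cc3)[nH]2)cc1`, gives 1600 nM in this assay.

Going by the values given here, on these two numbers compound 2 stands lowest, with compound 1 as the only neighbour, a 3.4-fold lower number from compound 1 to compound 2 (0.53 log units; beyond the scatter). The unmeasured compound 3, `O=C(O)c1ccccc1-c1ccc(CCc2ncc(Cc3ccccc3)[nH]2)cc1`, differs from compound 2 in one place: hydrogen in place of fluoro on an aromatic carbon. Among the compounds with values here, only one measured step touches the same position, the one from compound 1 to compound 2, where fluoro replaced methoxy, and it was modest in size. That step speaks only of two groups other than hydrogen, so what the bare phenyl does is not shown; the best reading of the single step is that this position answers to change, but not strongly. The expected step is therefore small, most likely a somewhat higher number in this assay as the fluoro is lost, though a change within the scatter cannot be ruled out. Compound 3 is estimated to give 2500 nM, within 1000 nM to 6500 nM, so the step of a 1.6-fold higher number from compound 2 to compound 3 (0.19 log units; within the scatter) is expected.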

Compound 3, half-maximal effective concentration: 205 nM
The estimate for compound 3 lay 12-fold (1.09 log units) above the measured number; the whole stated range lies above it.
By their numbers in this assay, from the lowest: compound 3; then compound 2; then compound 1.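

In this assay, the hydrogen at this position, on the aromatic carbon para to a large group, gives a result the earlier pair could not show: removing the fluoro gives a 7.8-fold lower number from compound 2 to compound 3 (0.89 log units; beyond the scatter), and replacing the methoxy with hydrogen gives a 26-fold lower number from compound 1 to compound 3 (1.42 log units; beyond the scatter). Among these three compounds, the two that carry a group at this position, whether fluoro or methoxy, both stand above the unsubstituted benzyl compound, so the change from 4-fluorobenzyl to benzyl matters more here than the comparison of the two substituted compounds could reveal. No measurement of any other kind accompanies these numbers, and nothing here accounts for this order.

Going by these compounds, it remains open whether other groups on the same aromatic carbon, such as chloro, methyl, hydroxyl or an amine, would also stand above the unsubstituted benzyl compound or would match it. On these data alone, it is also open whether the benzyl group would keep its standing if the carboxylic acid of the shared core gave way to an amide.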